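The source may report more compounds than this note shows. Statements on the series, on what has been measured and on what is new or still open speak of the compounds shown alone.

The measured compounds:
compound 1 `COc1ccc(S(=O)(=O)Nc2ccc(C)cc2Br)cc1N1CCNCC1` — 7.94 nM
compound 2 `COc1ccc(S(=O)(=O)Nc2cc(Cl)c(Cl)cc2Cl)cc1N1CCNCC1` — 5.01 nM

Both compounds were tested in an assay on isolated protein for binding affinity to 5-hydroxytryptamine receptor 6 (Homo sapiens); a lower number here means a stronger inhibitor, a higher number a weaker inhibitor. Compound 1 gives the larger of the two numbers shown, but the only step among them, a 1.6-fold lower number from compound 1 to compound 2 (0.20 log units; within the scatter), lies within the scatter, so no real difference between compound 1 and compound 2 is established by these data.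

Compound 3 `COc1ccc(S(=O)(=O)Nc2cc(Br)cc(Cl)c2Br)cc1N1CCNCC1` has not yet been measured in this assay. It differs from compound 1 in one place: 2,5-dibromo-3-chlorophenyl in place of 2-bromo-4-methylphenyl on a sulfonamide nitrogen. Within the data shown here, the one measured step that bears on this change is a 1.6-fold lower number from compound 1 to compound 2 (0.20 log units; within the scatter), where a halogen-bearing phenyl also replaced the 2-bromo-4-methylphenyl on the sulfonamide nitrogen, and that step stayed within the scatter. Among the measured compounds shown here, with no other step to draw on, a change beyond the scatter in this assay is not expected in either direction.

Compound 3 is therefore estimated to give about 6.3 nM, in a range from 2.5 nM to 16 nM. The step so expected, a 1.3-fold lower number from compound 1 to compound 3 (0.10 log units; within the scatter), is within the scatter.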

Compound 3, inhibition constant: 3.98 nM
Estimate against measurement, compound 3: 1.6-fold (0.20 log units) above, and the stated range covers the measured number.
By their numbers in this assay, from the lowest: compounds 3, 2 and 1 (each within the scatter of the next).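

In this assay, 2,5-dibromo-3-chlorophenyl on a sulfonamide nitrogen gives a 2.0-fold lower number from compound 1 to compound 3 (0.30 log units; within the scatter) when it replaces 2-bromo-4-methylphenyl, and a 1.3-fold lower number from compound 2 to compound 3 (0.10 log units; within the scatter) when it replaces 2,4,5-trichlorophenyl. With this third group, the comparison at this position now includes a phenyl that carries both bromine and chlorine, and neither new step establishes a real difference, so compound 1, compound 2 and compound 3 cannot be told apart by these numbers, whether the group carries a methyl, chlorine alone, or bromine with chlorine. No measurement is available that bears on why these groups give such similar numbers.

As far as these compounds go, all three groups on the sulfonamide nitrogen are phenyl rings bearing at least one halogen, so it remains open whether a plain phenyl, or a phenyl carrying an amine or a carboxylic acid, would give a step beyond the scatter in this assay. The rest of the core is the same in all three compounds, which leaves the effect of any change there on this number unknown.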